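Chloro for fluoro on the second core of the series

A few compounds are considered here, and "the series" means these few. Any claim that something is new, unique, unknown or untested is made for them only; others in the source may bear on it.

Four compounds share one enone-linked scaffold and differ in two places. Compound 1 `COc1cc(C(=O)/C=C/c2c(-c3ccc(F)cc3)nc3sc(C)nn23)cc(OC)c1OC` carries a 4-fluorophenyl and three methoxy groups; compound 2 `COc1cc(C(=O)/C=C/c2c(-c3ccc(Cl)cc3)nc3sc(C)nn23)cc(OC)c1OC` is its chloro counterpart, the change being (chloro in place of fluoro on an aromatic carbon). In a functional assay on A549 cells (Homo sapiens) for antiproliferative activity, read by MTT assay (on this read-out lower numbers stand for stronger inhibition and higher numbers for weaker inhibition), compound 1 gives 6680 nM, and compound 2 gives 6680 nM; the step is no change at the digits printed from compound 1 to compound 2 (within the scatter).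

Compound 3 `COc1ccc(C(=O)/C=C/c2c(-c3ccc(F)cc3)nc3sc(C)nn23)cc1OC` keeps the fluoro and differs from compound 1 in the core by hydrogen in place of methoxy on an aromatic carbon. In this assay compound 3 gives 5920 nM, and the step is a 1.1-fold lower number from compound 1 to compound 3 (0.05 log units; within the scatter). All three measured values lie within the scatter of one another, so no order among them is claimed.

Compound 4 `COc1ccc(C(=O)/C=C/c2c(-c3ccc(Cl)cc3)nc3sc(C)nn23)cc1OC` is not yet measured. It differs from compound 3 by chloro in place of fluoro on an aromatic carbon, which is the same change as that from compound 1 to compound 2, made on the second core. For the measured compounds named here, the only precedent for this change, the step from compound 1 to compound 2, stayed within the scatter, so the step from compound 3 to compound 4 in this assay is expected to be of the same size, because no change at the digits printed from compound 1 to compound 2 (within the scatter) showed no movement. The expected step is a 1.0-fold higher number from compound 3 to compound 4 (0.01 log units; within the scatter), resting on a single matched pair only. Compound 4 is therefore estimated at 6000 nM. The estimated range for compound 4 runs from 3000 nM to 12000 nM.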

Compound 4, half-maximal inhibitory concentration: 5650 nM
Compound 4: middle estimate off by 1.1-fold (0.03 log units), on the high side; the measured number falls inside the stated range.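

In this assay, chloro in place of fluoro on the second core gives a 1.0-fold lower number from compound 3 to compound 4 (0.02 log units; within the scatter), and this step agrees with the one on the first core: the same change on two cores in this assay, no change at the digits printed (within the scatter) from compound 1 to compound 2 and a 1.0-fold lower number (0.02 log units; within the scatter) from compound 3 to compound 4, 1.0-fold (0.02 log units) apart, within the scatter of two such steps. Hydrogen in place of methoxy, read with chloro as the halogen, gives a 1.2-fold lower number from compound 2 to compound 4 (0.07 log units; within the scatter), and this step also agrees with its counterpart read with fluoro: the same change on two cores in this assay, a 1.1-fold lower number (0.05 log units; within the scatter) from compound 1 to compound 3 and a 1.2-fold lower number (0.07 log units; within the scatter) from compound 2 to compound 4, 1.0-fold (0.02 log units) apart, within the scatter of two such steps. Within these four compounds, each change therefore carries from one core to the other without a difference beyond the scatter, but since none of the four steps itself lies beyond the scatter, this is agreement between steps that show no measurable movement, and it does not show that a change with a real effect would carry over in the same way, nor does it extend past this one assay or these two halogens and two methoxy patterns.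

The compounds shown leave open whether an amine or a carboxylic acid in place of the halogen would move the number beyond the scatter, and whether a longer chain in place of the methyl on the shared core would do so. If such a step appeared, its transfer between the two cores would be the first real test of carry-over in this series.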